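The compounds below may be only part of what the source reports. "The series", "measured", "known", "first", "only" and "open" are said of these compounds alone.

Measured compounds in a functional assay on HL-60 cells (Homo sapiens) for cytotoxicity, read by MTT assay, with a stated time of 72 h; on this read-out higher numbers stand for weaker inhibition and lower numbers for stronger inhibition:
compound 1, `Fc1ccc(-c2nnc3nnc(N4CCCC4)n3n2)cc1` — 4560 nM
compound 2, `c1ccc(-c2nnc3nnc(N4CCCC4)n3n2)cc1` — a limit of the assay, > 100000 nM
compound 3, `O=[N+]([O-])c1ccc(-c2nnc3nnc(N4CCCC4)n3n2)cc1` — a limit of the assay, > 100000 nM

Compound 3 stands at the ceiling of the run, as described by the limit of > 100000 nM in this assay, at which 2 of the 3 values shown sit; no number is known for it, only that it lies past the limit. The two readable steps in this assay are large: an at least 21-fold higher number from compound 1 to compound 2 (1.34 log units; beyond the scatter) and an at least 21-fold higher number from compound 1 to compound 3 (1.34 log units; beyond the scatter). The remaining pair is not readable, a step that the two limits leave unreadable from compound 2 to compound 3.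

Compound 4, `O=[N+]([O-])c1ccc(-c2nnc3nnc(N4CCCCC4)n3n2)cc1`, is unmeasured. It differs from compound 3 by piperidin-1-yl in place of pyrrolidin-1-yl on an aromatic carbon. Among the measured compounds shown here, none of the three measured steps touches this part of the core: each of them exchanges the group on an aromatic carbon of the six-membered ring, so no measured step bears on the size of the change from pyrrolidin-1-yl to piperidin-1-yl. With compound 3 already at the limit, the expectation in this assay is a step of no readable size beyond the scatter, and most likely a limit again. Compound 4 is therefore estimated at 120000 nM, in the range 30000 nM to 500000 nM. The expected step is a step that the limit leaves unreadable from compound 3 to compound 4.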

Compound 4, half-maximal inhibitory concentration: 610 nM
For compound 4 the middle estimate is 200-fold (2.29 log units) above the measured one, and the stated range ends above it.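

In this assay, piperidin-1-yl in place of pyrrolidin-1-yl gives an at least 160-fold lower number from compound 3 to compound 4 (2.21 log units; beyond the scatter), so this exchange lifts the nitro compound off the ceiling of the run. The earlier steps shown here all lay on the aromatic carbon of the six-membered ring, whereas this one shows that the read-out also answers strongly to the amine on the aromatic carbon of the five-membered ring, between two ring nitrogen atoms. The full size of the step stays unknown because compound 3 stands at a limit of the assay: the limit of > 100000 nM in this assay, at which 2 of the 4 values shown sit.

Open, from the compounds shown here alone, is whether piperidin-1-yl acts in the same way with fluoro or hydrogen in place of nitro on the aromatic carbon. Also open, going by these compounds, is how morpholin-4-yl, azepan-1-yl or an open-chain dimethylamino group would read at this place.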